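Cytotoxicity notes on the ester-to-amide swap

This account rests on a few compounds, and the source may have more. Where it says the series, first, only, none or still open, it means among the compounds named here.

Three members of the series have been run in an ADME assay on HepG2 2.2.15 cells (Homo sapiens) for cytotoxicity; on this read-out lower numbers stand for higher toxicity in this test and higher numbers for lower toxicity in this test. Compound 1 `CC(C)(C)OC(=O)Nc1ncc(C(Oc2ccc3cc(Br)ccc3c2)c2ccc(Cl)cc2)s1` gives > 50000 nM, which is a limit of the assay rather than a number, and it sits at the limit of > 50000 nM in this assay, at which 1 of the 3 values shown sits. Compound 2 `COCCNc1ncc(C(Oc2ccc3cc(Br)ccc3c2)c2ccc(Cl)cc2)s1` is recorded as "not toxic" (no number reported) in this assay, with no figure attached. Compound 3 `CCOC(=O)CCCNc1ncc(C(Oc2ccc3cc(Br)ccc3c2)c2ccc(Cl)cc2)s1` likewise comes out as "not toxic" (no number reported) in this assay, again without a number. Among the measured compounds shown here, compound 3 therefore stands without a single value; the two companion entries are one limit and one further entry without a number, so no ranking among the three is possible, and no step between measured compounds is available.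

Compound 4 `CCCCCC(=O)Nc1ncc(C(Oc2ccc3cc(Br)ccc3c2)c2ccc(Cl)cc2)s1` is the next member awaiting measurement. It differs from compound 3 by pentylcarbonyl in place of 3-(ethoxycarbonyl)propyl on a nitrogen on an aromatic ring. With all three measured compounds giving no sign of toxicity in this assay, there is nothing in the data that points to a shift in either direction for compound 4; the expectation is a step that does not go beyond the scatter, most likely another limit rather than a number. Compound 4 is accordingly estimated at 50000 nM in this assay, with a range from 20000 nM to 100000 nM.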

Compound 4, half-maximal cytotoxic concentration: > 50000 nM
Compound 4: a limit, no number; the forecaster's own chance of this, stated with the estimate: 70%; the middle value sits exactly at the limit.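

In this assay compound 4 gives > 50000 nM, a limit and not a number. Compound 1 gives > 50000 nM, also a limit, so no step can be read between compound 1 and compound 4. The compounds shown leave open how the four rank on half-maximal cytotoxic concentration, since none of them has a single number.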